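A few compounds are considered here, and "the series" means these few. Any claim that something is new, unique, unknown or untested is made for them only; others in the source may bear on it.

Measured so far:
Compound 1, `O=C(Nc1ccc(Cl)c(-c2nnc3c(Cl)cccn23)c1)c1ccc(C(F)(F)F)cc1F`: 41200 nM
Compound 2, `O=C(Nc1ccc(Cl)c(-c2nnc3c(Cl)cccn23)c1)c1ccccc1`: 67600 nM

Both compounds were tested in a functional assay on AN3-CA cells (Homo sapiens) for antiproliferative activity, read by MTT assay, with a stated time of 72 h; a lower number here means a stronger inhibitor, a higher number a weaker inhibitor. Compound 2 gives the higher of the two numbers, yet its gap to compound 1 lies within the scatter, so the two cannot be told apart on these data. Among the compounds with values here, the two compounds share a core and differ only in what sits on the benzoyl ring, and no single-change step between them is recorded.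

Compound 3, `O=C(Nc1ccc(Cl)c(-c2nnc3c(Cl)cccn23)c1)c1ccccc1Cl`, has not yet been measured in this assay. It differs from compound 2 in one place: chloro in place of hydrogen on an aromatic carbon. Since compound 1, which also carries groups on that ring, gives 41200 nM, no clear move in either direction is expected. The expected step is estimated as a 1.3-fold lower number from compound 2 to compound 3 (0.11 log units; within the scatter). Compound 3 is therefore expected to give about 52000 nM, most likely between 22000 nM and 120000 nM.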

Compound 3, half-maximal inhibitory concentration: > 100000 nM
Compound 3: only a limit was reported (the forecaster's own chance of this, stated with the estimate: 25%); middle value at least 1.9-fold (0.28 log units) from the limit.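

Chloro in place of hydrogen on this aromatic carbon, ortho to a large group, gives an at least 1.4-fold higher number from compound 2 to compound 3 (0.17 log units; that floor lies within the scatter). This is the only single-change step on the benzoyl ring among the compounds shown, and in this assay it gives no sign of a stronger inhibitor, although the floor of the step alone does not establish a real weakening. The true size of the step cannot be read because the value of compound 3 is a limit and not a number: the limit of > 100000 nM in this assay, at which 1 of the 3 values shown sits.

The compounds shown leave open whether a different group on this same carbon, such as methoxy, an amine or a carboxylic acid, would give a lower number than compound 2. They also leave open whether chloro on another carbon of this ring would give a measurable value.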